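The source may hold more compounds than are shown below. What is called first, only, known or untested is meant among the compounds shown, and "the series" means these compounds.

Measured so far:
- compound 2, `COc1nc2c(cc1Cc1cccc(Cl)c1F)c(=O)c(C(=O)O)cn2[C@H](CO)C(C)(C)C`: 82%
- compound 3, `CC(C)(C)[C@@H](CO)n1cc(C(=O)O)c(=O)c2cc(Cc3cccc(Cl)c3F)c(O)nc21`: 87%
- compound 1, `CCC[C@@H](CO)n1cc(C(=O)O)c(=O)c2cc(Cc3cccc(Cl)c3F)c(OC)nc21`: "not determined" (no result reported)

These compounds were tested in an ADME assay on microsomes from liver (Homo sapiens) for metabolic stability, with a stated time of 30 min; on this read-out lower numbers stand for a less stable compound and higher numbers for a more stable compound. Compound 2 gives 82% and compound 3 gives 87% in this assay; the two numbers lie within the scatter of each other, so neither can be called more or less stable than the other. Compound 1 has no result in this assay, so compound 3 is compared only with compound 2.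

Going by the values given here, the one step measured so far is a number 5 percentage points higher from compound 2 to compound 3 (within the scatter). The new compound 4, `CCOc1nc2c(cc1Cc1cccc(Cl)c1F)c(=O)c(C(=O)O)cn2[C@H](CO)C(C)(C)C`, is built from compound 3 by the change (ethyl in place of hydrogen on an oxygen on an aromatic ring). This is the same kind of change as the measured step, but run the other way and with a longer group: in the measured step an alkyl group on the ring oxygen was removed, here one is added. Since that step stayed within the scatter, there is no sign in these data that such a change moves this assay much in either direction.

Compound 4 is therefore expected to stay close to compound 3, with an estimated step of a number 5 percentage points lower from compound 3 to compound 4 (within the scatter). The expected value for compound 4 is 82%, within a range from 64% to 95%.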

Compound 4, percent of the compound remaining: 84%
For compound 4 the middle estimate is 2 percentage points below the measured one, and the stated range covers the measured number.
By their numbers in this assay, from the lowest: compounds 2, 4 and 3 (each within the scatter of the next).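

With ethyl in place of hydrogen on an oxygen on an aromatic ring, this assay shows a number 3 percentage points lower from compound 3 to compound 4 (within the scatter) and so the hydroxy and ethoxy compounds cannot be told apart by this read-out. A second comparison now exists at the same oxygen: methyl in place of hydrogen on a saturated chain carbon bound to that oxygen gives a number 2 percentage points higher from compound 2 to compound 4 (within the scatter) and so the methoxy and ethoxy compounds cannot be told apart either. The earlier compounds shown here offered a single step between hydroxy and methoxy, whereas all three groups can now be compared, and each pair lies within the scatter, so across these three compounds the group on this oxygen makes no readable difference to how much compound remains.

Going by these compounds, whether that holds for a longer chain on this oxygen, such as propyl, or for an amine in place of the oxygen remains open. No measurement given here speaks to why these three compounds read so alike.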